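Lengthening the Alkenyl Chain on the Amide Carbonyl

The source may report more compounds than this note shows. Statements on the series, on what has been measured and on what is new or still open speak of the compounds shown alone.

The three measured compounds share one core and differ only in the group on the carbonyl carbon. In a functional assay on HCT-116 cells (Homo sapiens) for inhibition, read by MTT assay, with a stated time of 48 h (a lower number here means a stronger inhibitor, a higher number a weaker inhibitor), compound 1 `COc1ccc(CN(C(=O)CN=[N+]=[N-])c2cc(OC)c(OC)c(OC)c2)cc1O` gives 410 nM, compound 2 `C/C=C/C(=O)N(Cc1ccc(OC)c(O)c1)c1cc(OC)c(OC)c(OC)c1` gives 55 nM, and compound 3 `C=CC(=O)N(Cc1ccc(OC)c(O)c1)c1cc(OC)c(OC)c(OC)c1` gives 98 nM. Compound 3 thus stands second highest of the three numbers: its gap to compound 2 is within the scatter, while a 4.2-fold lower number from compound 1 to compound 3 (0.62 log units; beyond the scatter) lies beyond it. Compound 4 `CC/C=C/C(=O)N(Cc1ccc(OC)c(O)c1)c1cc(OC)c(OC)c(OC)c1` carries but-1-en-1-yl in place of vinyl on a carbonyl carbon. The step that bears on this is a 1.8-fold higher number from compound 2 to compound 3 (0.25 log units; within the scatter), a change within the scatter, so adding chain length at this position has so far shown no clear effect. Compound 4 is therefore expected to sit close to compound 3, with a 1.4-fold lower number from compound 3 to compound 4 (0.15 log units; within the scatter) small and, if anything, toward a lower number. Compound 4 is estimated at 70 nM, within 30 nM to 160 nM.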

Compound 4, half-maximal inhibitory concentration: 63 nM
Compound 4: the middle estimate sits 1.1-fold (0.05 log units) above what was measured; low and high end bracket the measured number.
By their numbers in this assay, from the lowest: compounds 2, 4 and 3 (each within the scatter of the next); then compound 1.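

In this assay, extending the alkenyl chain to but-1-en-1-yl on the carbonyl carbon gives no resolved change: neither a 1.6-fold lower number from compound 3 to compound 4 (0.19 log units; within the scatter) nor a 1.1-fold higher number from compound 2 to compound 4 (0.06 log units; within the scatter) lies beyond the scatter. Across vinyl, prop-1-en-1-yl and but-1-en-1-yl, the response therefore stays flat. The separation from the azidomethyl compound also persists with the longer chain, at a 6.5-fold lower number from compound 1 to compound 4 (0.81 log units; beyond the scatter). From the compounds shown here alone, whether a saturated butyl group, a longer alkenyl chain or an amine on this carbonyl carbon would keep this level remains open. Nothing available explains the flat response.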